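Moving the Hydroxy Group Around the Saturated Ring

This account rests on a few compounds, and the source may have more. Where it says the series, first, only, none or still open, it means among the compounds named here.

Compound 1 `Cn1nc(-c2ccc(C(N)=O)cc2)s/c1=N\C1CCCCC1`: 7.65 L/kg
Compound 2 `Cn1nc(-c2ccc(C(N)=O)cc2)s/c1=N\C1CCCCC1O`: 1.47 L/kg
Compound 3 `Cn1nc(-c2ccc(S(C)(=O)=O)cc2)s/c1=N\c1cccc(C(=O)O)c1`: 7.58 L/kg

In an in vivo ADME assay on the whole organism for pharmacokinetics, at a dose of 0.5 mg/kg by the intravenous route (a lower number here means that more of the compound stays in the plasma, a higher number that more of the compound sits outside the plasma), compound 2 gives the lowest of the three numbers, and both compound 1 and compound 3 sit well above it, each beyond the scatter. Among the compounds with values here, the only step measured so far that touches this part of the molecule is the one from compound 1 to compound 2, the introduction of a hydroxy group, which gave a 5.2-fold lower number from compound 1 to compound 2 (0.72 log units; beyond the scatter).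

Compound 4 `Cn1nc(-c2ccc(C(N)=O)cc2)s/c1=N\C1CCC(O)CC1` differs from compound 2 by 4-hydroxycyclohexyl in place of 2-hydroxycyclohexyl on a double-bonded nitrogen; the two have the same atoms, joined differently. Within the data shown here, no measured step moves a hydroxy group from one saturated ring carbon to another, so nothing shows how much position matters once the group is present. The step of a 1.4-fold higher number from compound 2 to compound 4 (0.13 log units; within the scatter) is therefore expected to stay within the scatter, with a slight lean upward. Compound 4 is estimated at 2 L/kg, between 0.9 L/kg and 4.5 L/kg.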

Compound 4, volume of distribution: 0.98 L/kg
The estimate for compound 4 lay 2.0-fold (0.31 log units) above the measured number, and the stated range covers the measured number.
By their numbers in this assay, from the lowest: compounds 4 and 2 (each within the scatter of the next); then compounds 3 and 1 (each within the scatter of the next).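

Going from 2-hydroxycyclohexyl to 4-hydroxycyclohexyl in this assay gives a 1.5-fold lower number from compound 2 to compound 4 (0.18 log units; within the scatter) and so does not separate these two placements of the hydroxy group. Placing it as 4-hydroxycyclohexyl still gives a 7.8-fold lower number from compound 1 to compound 4 (0.89 log units; beyond the scatter) much as 2-hydroxycyclohexyl did, so the lower number is not tied to just one of these two ring carbons. On these data alone, whether an amine or a methoxy group on the same saturated ring would lower the number as the hydroxy group does stays open. Nothing shown here explains why the hydroxy group lowers it.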